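Fluoro in Place of Methyl: Tolerability Expected to Stay High

The compounds below may be only part of what the source reports. "The series", "measured", "known", "first", "only" and "open" are said of these compounds alone.

Three compounds share one core. In an ADME assay on cells (Homo sapiens) for cytotoxicity, read by resazurin assay, with a stated time of 5 days (a higher number here means that more compound is tolerated, a lower number that less compound is tolerated), compound 1 `COc1ccc(-c2nc(C(C)(C)S(=O)(=O)c3cccc(Cl)c3)nc3ccsc23)cn1` reaches only the limit > 50000 nM. Compound 2 `COc1ccc(-c2nc(C(C)S(=O)(=O)c3cccc(Cl)c3)nc3ccsc23)cn1` likewise gives only the limit > 50000 nM in this assay. Compound 3 `COc1ccc(-c2nc(CSc3cccc(Cl)c3)nc3ccsc23)cn1` gives the limit > 10000 nM. Compound 2 therefore stands at the limit of > 50000 nM in this assay, at which 2 of the 3 values shown sit, while one other value sits at the limit of > 10000 nM in this assay, at which 1 of the 3 values shown sits. The single step that bears on the change ahead, a step that the two limits leave unreadable from compound 1 to compound 2, is shown as unreadable, so its size is unknown. The unmeasured compound 4 `COc1ccc(-c2nc(C(F)S(=O)(=O)c3cccc(Cl)c3)nc3ccsc23)cn1` differs from compound 2 by fluoro in place of methyl on a saturated chain carbon bound to an aromatic carbon and a sulfonyl sulfur. With no readable step to draw on, no shift beyond the scatter is expected in either direction, and a further limit is the most likely result. Compound 4 is expected to give 50000 nM, within a range from 20000 nM to 100000 nM. The estimated step of a number no higher from compound 2 to compound 4 (the limit leaves the size open) is expected to be none beyond the scatter.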

Compound 4, half-maximal cytotoxic concentration: > 50000 nM
Compound 4 gave a limit, no number (the forecaster's own chance of this, stated with the estimate: 80%); the middle value sits exactly at the limit.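

In this assay compound 4 gives > 50000 nM, which is a limit and not a number. Compound 2 also gives only a limit, and the step between compound 2 and compound 4 cannot be read. The compounds shown leave open the concentration at which either one becomes toxic to cells.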